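From pyridin-3-yl to pyridin-4-yl at the assay limit

The source may report more compounds than this note shows. Statements on the series, on what has been measured and on what is new or still open speak of the compounds shown alone.

Of the compounds shown here, three sharing one core have been tested so far. In a functional assay on cells (Platelet, Homo sapiens) for inhibition (a lower number here means a stronger inhibitor, a higher number a weaker inhibitor), compound 1 (`CCOC(=O)c1ccc(-c2nn(Cc3ccc(Cl)cc3)c3ccccc23)cc1`) gives > 10000 nM as a limit of the assay. Compound 2 (`CCOC(=O)c1ccc(-c2nn(Cc3ccccc3OC)c3ccccc23)cc1`) gives > 10000 nM in this assay and this too is a limit. Compound 3 (`CCOC(=O)c1ccc(-c2nn(Cc3cccnc3)c3ccccc23)cc1`) gives > 10000 nM in this assay and this is again a limit, so it has no number of its own. Among the measured compounds shown here, the series so far stands at the limit of > 10000 nM in this assay, at which 3 of the 3 values shown sit, and no measured number is available yet.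

Compound 4 (`CCOC(=O)c1ccc(-c2nn(Cc3ccncc3)c3ccccc23)cc1`) carries pyridin-4-yl in place of pyridin-3-yl on a saturated chain carbon bound to an aromatic nitrogen. Three measured changes at this same place bear on it. For the measured compounds named here, the first is a step that the two limits leave unreadable from compound 1 to compound 2 and the second is a step that the two limits leave unreadable from compound 1 to compound 3 while the third is a step that the two limits leave unreadable from compound 2 to compound 3 and so none offers a size to carry over. No step beyond the scatter and no direction can therefore be expected in this assay with any support. The expected outcome is a step that the limit leaves unreadable from compound 3 to compound 4 and this remains an estimate only. The estimate for compound 4 is 15000 nM with an expected range from 5000 nM to 40000 nM and a report as a limit is the likeliest result.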

Compound 4, half-maximal inhibitory concentration: > 10000 nM
Compound 4: no number, only a limit (the forecaster's own chance of this, stated with the estimate: 80%); the middle value does not contradict the limit.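

In this assay compound 4 gives > 10000 nM, which is again a limit. No new step can be read between compound 4 and compound 1, compound 2 or compound 3, as each pair joins two limits. The series now stands at one value: the limit of > 10000 nM in this assay, at which 4 of the 4 values shown sit. The compounds shown leave open whether any group at this place gives a measurable inhibition.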